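Terminal group swap on the hydroxy compound

This account rests on a few compounds, and the source may have more. Where it says the series, first, only, none or still open, it means among the compounds named here.

Measured in a functional assay on PC-3 cells (Homo sapiens) for inhibition, read by sulforhodamine B assay; a lower number here means a stronger inhibitor of growth, a higher number a weaker inhibitor of growth:
- compound 1 `FC(F)(F)c1ccc(-c2ccc(-c3ccc(-c4nc5ccccc5[nH]4)cc3)cc2)cc1`: 45200 nM
- compound 2 `Oc1cccc2[nH]c(-c3ccc(-c4ccc(-c5ccc(C(F)(F)F)cc5)cc4)cc3)nc12`: 2260 nM

Not yet measured: compound 3 `COc1ccc(-c2ccc(-c3ccc(-c4nc5c(O)cccc5[nH]4)cc3)cc2)cc1`

In this assay, compound 2 holds the lower of the two numbers at 2260 nM. The next change is methoxy in place of trifluoromethyl on an aromatic carbon, para to a large group. Within the data shown here, the only measured step, a 20-fold lower number from compound 1 to compound 2 (1.30 log units; beyond the scatter), is large, but it is a different change, hydroxy in place of hydrogen. Among the measured compounds shown here, no measured step covers the new change, so no direction can be drawn from the data, and no shift beyond the scatter is expected. The expected step is a 1.1-fold higher number from compound 2 to compound 3 (0.04 log units; within the scatter). The estimate for compound 3 is 2500 nM, with an expected range of 700 nM to 9000 nM.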

Compound 3, concentration for 50% growth inhibition: 6610 nM
For compound 3 the middle estimate is 2.6-fold (0.42 log units) below the measured one; measured number inside the range.
By their numbers in this assay, from the lowest: compound 2; then compound 3; then compound 1.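

In this assay, the terminal group on the hydroxy compound affects the result: going from 4-(trifluoromethyl)phenyl to 4-methoxyphenyl gives a modest step (a 2.9-fold higher number from compound 2 to compound 3 (0.47 log units; beyond the scatter)). On this aromatic carbon, para to a large group, trifluoromethyl therefore gives the lower number of the two groups compared. No measurement available here bears on the reason for this step.

Still open, going by these compounds, is how an amine, a carboxylic acid or a longer chain would read at this carbon. The compounds shown also leave open whether the same swap would give a similar step without the hydroxy group on the core.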